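Removing a Methoxy Group from Compound 1

A few compounds are considered here, and "the series" means these few. Any claim that something is new, unique, unknown or untested is made for them only; others in the source may bear on it.

Measured so far:
Compound 1 `COc1ccc(-c2ccc(C(=O)NCCCCc3cccnc3)cc2OC)cc1OC`: 300 nM
Compound 2 `CCc1cc(C(=O)N[C@H](C)CCCc2cccnc2)ccc1-c1ccc(OC)c(OC)c1`: 4 nM
Compound 3 `C=CCc1cc(C(=O)N[C@H](C)CCCc2cccnc2)ccc1-c1ccc(OC)c(OC)c1`: 80 nM

In an assay (Canis lupus familiaris) for binding affinity to platelet-activating factor receptor (Homo sapiens), read by radioligand binding (a higher number here means a weaker inhibitor, a lower number a stronger inhibitor), compound 1 gives the highest number of the three. Compound 4 `COc1ccc(-c2ccc(C(=O)NCCCCc3cccnc3)cc2)cc1OC` differs from it by hydrogen in place of methoxy on an aromatic carbon. Going by the values given here, no measured pair tests this exact change. Among the compounds with values here, the only single step in the set, a 20-fold higher number from compound 2 to compound 3 (1.30 log units; beyond the scatter), sits at the same aromatic carbon and shows that swapping one group there for another can move the number a great deal. Compounds 2 and 3 also carry an added methyl on the chain, so they cannot be read directly against compound 1. With so little to go on, compound 4 is expected to land near compound 1, perhaps somewhat weaker, estimated at 600 nM within 150 nM to 2500 nM, a step of a 2.0-fold higher number from compound 1 to compound 4 (0.30 log units; within the scatter).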

Compound 4, half-maximal inhibitory concentration: 400 nM
Beside the measured number, compound 4's estimate is 1.5-fold (0.18 log units) above it; the range from low to high includes it.
By their numbers in this assay, from the lowest: compound 2; then compound 3; then compounds 1 and 4 (each within the scatter of the next).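

A step of a 1.3-fold higher number from compound 1 to compound 4 (0.12 log units; within the scatter) is what hydrogen in place of methoxy gives in this assay, so on this core the methoxy can go without a change beyond the scatter. That contrasts with a 20-fold higher number from compound 2 to compound 3 (1.30 log units; beyond the scatter) at the same aromatic carbon, though those two compounds also carry an added methyl on the chain. No measurement shown explains this result.

Still open, as far as these compounds go, is whether an amine, a carboxylic acid or a longer chain on this carbon would move the number. Also open, from the compounds shown here alone, is whether hydrogen there would give a similar result in compounds with the added methyl.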